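This account rests on a few compounds, and the source may have more. Where it says the series, first, only, none or still open, it means among the compounds named here.

Of the compounds shown here, three from one series have been measured, and a fourth is still waiting. Compound 1 `CCCN1C(=O)COc2cc(CNc3ccccc3C)ccc21`, compound 2 `CCCCN1C(=O)COc2cc(CNc3ccccc3C)ccc21` and compound 3 `CCCN1C(=O)COc2cc(CNc3cccc(C)c3)ccc21` were tested in a functional assay on a cell-free system (Platelet, plasma, Oryctolagus cuniculus) for inhibition, with stated times of 5 min and 6 min; a higher number here means a weaker inhibitor, a lower number a stronger inhibitor. In this assay compound 1 gives 18800 nM. Compound 2 gives 18800 nM in this assay. Compound 3 gives 13900 nM in this assay.

Compound 2 differs from compound 1 only by methyl in place of hydrogen on a saturated chain carbon, three bonds along the chain from an amide-type nitrogen in a ring. That step is no change at the digits printed from compound 1 to compound 2 (within the scatter). Compound 3 differs from compound 1 in its core by 3-methylphenyl in place of 2-methylphenyl on an amine nitrogen, and that step is a 1.4-fold lower number from compound 1 to compound 3 (0.13 log units; within the scatter). All three numbers therefore sit within the usual scatter of one another, and none of the three can be called stronger or weaker than another.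

Compound 4 `CCCCN1C(=O)COc2cc(CNc3cccc(C)c3)ccc21` has not yet been measured. It differs from compound 3 by methyl in place of hydrogen on a saturated chain carbon, three bonds along the chain from an amide-type nitrogen in a ring. This is the same change, at the same place, as the one separating compound 1 from compound 2; among the compounds shown it appears in two pairs, one measured and one not. Because the measured example no change at the digits printed from compound 1 to compound 2 (within the scatter) lay within the scatter, the step expected for compound 4 is a 1.0-fold higher number from compound 3 to compound 4 (0.00 log units; within the scatter) in this assay. On that basis compound 4 is estimated to give about 14000 nM in this assay, most likely somewhere between 7000 nM and 28000 nM.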

Compound 4, half-maximal inhibitory concentration: 12700 nM
Compound 4: the middle estimate sits 1.1-fold (0.04 log units) above what was measured; the range from low to high includes it.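

Among the compounds shown here, the step from propyl to butyl on the amide-type nitrogen in a ring, read here on the second core, is a 1.1-fold lower number from compound 3 to compound 4 (0.04 log units; within the scatter) in this assay, and it agrees with the earlier example of the same change: the same change on two cores in this assay, no change at the digits printed (within the scatter) from compound 1 to compound 2 and a 1.1-fold lower number (0.04 log units; within the scatter) from compound 3 to compound 4, 1.1-fold (0.04 log units) apart, within the scatter of two such steps The swap of 2-methylphenyl for 3-methylphenyl on the amine nitrogen, read here with the butyl chain in place, is a 1.5-fold lower number from compound 2 to compound 4 (0.17 log units; within the scatter), and it also agrees with its earlier example: the same change on two cores in this assay, a 1.4-fold lower number (0.13 log units; within the scatter) from compound 1 to compound 3 and a 1.5-fold lower number (0.17 log units; within the scatter) from compound 2 to compound 4, 1.1-fold (0.04 log units) apart, within the scatter of two such steps Both changes therefore behave alike on the two cores, with neither producing a step beyond the scatter, but this shows only that two small changes stay small; it does not show that a change with a clear effect would carry from one core to another in the same way.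

The compounds shown leave open whether any group at these two places can move the number beyond the scatter, such as a longer chain, or a chain ending in an amine or a carboxylic acid, on the amide-type nitrogen. Going by these compounds, it also remains open whether a phenyl carrying something other than methyl, such as a carboxylic acid, would give a clear step, and whether that step would hold on both cores.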